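Removing the amide link: from compound 3 to compound 4

This account rests on a few compounds, and the source may have more. Where it says the series, first, only, none or still open, it means among the compounds named here.

The measured compounds so far:
compound 1, `Nc1ncc(-c2cnn(C3CCNCC3)c2)cc1-c1nc2ccc(OCc3ccccc3)cc2o1`, 6900 nM in an assay on isolated protein for inhibition of G protein-coupled receptor kinase 5 (Homo sapiens), read by TR-FRET, with stated times of 10 min and 1 h; a higher number here means a weaker inhibitor, a lower number a stronger inhibitor;
compound 2, `Nc1ncc(-c2cnn(C3CCNCC3)c2)cc1-c1nc2ccc(NC(=O)c3ccccc3)cc2o1`, 3490 nM;
compound 3, `COc1ccc(C(=O)Nc2ccc3nc(-c4cc(-c5cnn(C6CCNCC6)c5)cnc4N)oc3c2)cc1`, 2090 nM.

Compound 3 stands at the lowest number of the three. Its gap to compound 2 is small: a 1.7-fold lower number from compound 2 to compound 3 (0.22 log units; within the scatter). Its gap to compound 1 is clearer: a 3.3-fold lower number from compound 1 to compound 3 (0.52 log units; beyond the scatter). The remaining step, a 2.0-fold lower number from compound 1 to compound 2 (0.30 log units; within the scatter), is also small.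

Compound 4 is `COc1ccc(-c2ccc3nc(-c4cc(-c5cnn(C6CCNCC6)c5)cnc4N)oc3c2)cc1`. It differs from compound 3 in one place: 4-methoxyphenyl in place of ((4-methoxyphenyl)carbonyl)amino on an aromatic carbon. The methoxyphenyl group itself stays, but the amide between it and the shared core is gone, so the ring is joined directly.

None of the three measured steps tests this kind of change. The steps that exist swap one whole side group for another or add a methoxy to a ring that is already there; they say nothing about shortening the link. For the measured compounds named here, with no comparable step to lean on, the expected outcome for compound 4 is a number close to that of compound 3, with a wide range in either direction. The estimated step is a 1.4-fold higher number from compound 3 to compound 4 (0.16 log units; within the scatter), and compound 4 is estimated at 3000 nM, between 900 nM and 10000 nM.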

Compound 4, half-maximal inhibitory concentration: 3220 nM
The estimate for compound 4 lay 1.1-fold (0.03 log units) below the measured number, and the stated range covers the measured number.
By their numbers in this assay, from the lowest: compounds 3, 4, 2 and 1 (each within the scatter of the next, the first and the last beyond it).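

In this assay, this position tolerates losing the amide link: a 1.5-fold higher number from compound 3 to compound 4 (0.19 log units; within the scatter), so removing the carbonyl and the amide hydrogen while keeping the 4-methoxyphenyl ring leaves the number within the scatter. Compound 4 also sits level with the benzamido compound, a 1.1-fold lower number from compound 2 to compound 4 (0.03 log units; within the scatter), while the change from benzyloxy, a 2.1-fold lower number from compound 1 to compound 4 (0.33 log units; beyond the scatter), goes just beyond the scatter and is modest. No measurement shown here explains why the link matters so little.

From the compounds shown here alone, every group compared at this position carries a six-membered aromatic ring of carbon only, so it remains open how a much smaller group, such as a single amine, or a longer chain would behave there. Going by these compounds, it is also open whether a carboxylic acid in place of the methoxy on the directly joined ring would shift the number.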